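Swapping Naphthalenyl for Fluorophenyl on the Shared Core

A few compounds are considered here, and "the series" means these few. Any claim that something is new, unique, unknown or untested is made for them only; others in the source may bear on it.

Within the data shown here, compound 3 `O=C1N/C(=N/c2nc(-c3ccc(Cl)cc3)cs2)S/C1=C\c1ccc2ccccc2c1` gives the highest of the three numbers so far in a functional assay on HCT-116 cells (Homo sapiens) for cytotoxicity, read by MTT assay, with a stated time of 72 h (a lower number here means a stronger inhibitor, a higher number a weaker inhibitor), at 1200 nM. Compound 1 `CN(C)c1ccc(/C=C2\S/C(=N\c3nc(-c4ccc(Cl)cc4)cs3)NC2=O)cc1` gives 200 nM and compound 2 `COc1ccc(/C=C2\S/C(=N\c3nc(-c4ccc(Cl)cc4)cs3)NC2=O)cc1` gives 400 nM. The steps of a 6.0-fold higher number from compound 1 to compound 3 (0.78 log units; beyond the scatter) and a 3.0-fold higher number from compound 2 to compound 3 (0.48 log units; beyond the scatter) both ran upward when a naphthalen-2-yl replaced a substituted phenyl ring, while a 2.0-fold higher number from compound 1 to compound 2 (0.30 log units; within the scatter) stayed small. Compound 4 `O=C1N/C(=N/c2nc(-c3ccc(Cl)cc3)cs2)S/C1=C\c1ccc(F)cc1` reverses that kind of change: 4-fluorophenyl in place of naphthalen-2-yl on a double-bonded chain carbon bound to a double-bonded ring carbon. Because of a 6.0-fold higher number from compound 1 to compound 3 (0.78 log units; beyond the scatter) and a 3.0-fold higher number from compound 2 to compound 3 (0.48 log units; beyond the scatter) a modest downward step is expected, although a fluorine on that ring has not been tested here. Compound 4 is therefore estimated at 500 nM in this assay, with a likely range from 200 nM to 1500 nM. That corresponds to an expected 2.4-fold lower number from compound 3 to compound 4 (0.38 log units; beyond the scatter).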

Compound 4, half-maximal inhibitory concentration: 7500 nM
Estimate against measurement, compound 4: 15-fold (1.18 log units) below; the measured number lies above the stated range.
By their numbers in this assay, from the lowest: compounds 1 and 2 (each within the scatter of the next); then compound 3; then compound 4.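

In this assay, swapping to 4-fluorophenyl gives a 6.3-fold higher number from compound 3 to compound 4 (0.80 log units; beyond the scatter) and so gives the highest number of the four compounds. A phenyl ring at this place therefore does not by itself give a low number, and what the ring carries matters: fluoro gives a 19-fold higher number from compound 2 to compound 4 (1.27 log units; beyond the scatter) when it replaces methoxy and a 38-fold higher number from compound 1 to compound 4 (1.57 log units; beyond the scatter) when it replaces dimethylamino. No measured evidence is available to explain these steps.

Still open, going by these compounds, is how a phenyl ring with no added group would stand on the shared core. On these data alone, a ring carrying hydroxyl or amino in that place is also open.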